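The source may report more compounds than this note shows. Statements on the series, on what has been measured and on what is new or still open speak of the compounds shown alone.

For the measured compounds named here, compound 1 `Cn1c(=O)c2c(nc(SCc3ccccc3)n2C)n(C)c1=O` gives 1860 nM in an assay on isolated protein for inhibition of Amine oxidase [flavin-containing] B (Homo sapiens), read by fluorescence (on this read-out lower numbers stand for stronger inhibition and higher numbers for weaker inhibition), the highest of the three numbers measured so far. Compound 2 `Cn1c(=O)c2c(nc(SCCOc3ccccc3)n2C)n(C)c1=O` gives 332 nM and compound 3 `Cn1c(=O)c2c(nc(SCc3ccc(Br)cc3)n2C)n(C)c1=O` gives 167 nM; a 5.6-fold lower number from compound 1 to compound 2 (0.75 log units; beyond the scatter) and an 11-fold lower number from compound 1 to compound 3 (1.05 log units; beyond the scatter), while a 2.0-fold lower number from compound 2 to compound 3 (0.30 log units; within the scatter). Compound 4 `Cn1c(=O)c2c(nc(SC3CCCCC3)n2C)n(C)c1=O` differs from compound 1 by cyclohexyl in place of benzyl on a sulfur. Both measured steps kept the aromatic ring on the group bound to the sulfur and extended or substituted it, so they bear on this change only loosely and give no direction for removing that ring altogether. A small step, if any, is expected, with a somewhat higher number slightly more likely. For compound 4 the estimate is 3000 nM, expected to lie between 800 nM and 12000 nM, which would mean a 1.6-fold higher number from compound 1 to compound 4 (0.21 log units; within the scatter).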

Compound 4, half-maximal inhibitory concentration: 13100 nM
The estimate for compound 4 lay 4.4-fold (0.64 log units) below the measured number; measured number outside the range, above it.
By their numbers in this assay, from the lowest: compounds 3 and 2 (each within the scatter of the next); then compound 1; then compound 4.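

In this assay, for the compounds shown here, cyclohexyl in place of benzyl on the sulfur gives a 7.0-fold higher number from compound 1 to compound 4 (0.85 log units; beyond the scatter), the first step here to remove the aromatic ring from this group, and it goes towards weaker inhibition. At this position, then, a non-aromatic ring of carbon only does not match benzyl. Nothing given here accounts for this step. The change also removes the saturated carbon of benzyl, so the compounds shown do not separate the two losses. On these data alone, whether cyclohexylmethyl or a directly attached phenyl on the sulfur would restore inhibition remains open.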